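The source may hold more compounds than are shown below. What is called first, only, known or untested is meant among the compounds shown, and "the series" means these compounds.

Of the compounds shown here, three sharing one core have been measured in an assay on isolated protein for inhibition of glutathione S-transferase Mu 2 (Homo sapiens), with a stated time of 10 min; a higher number here means a weaker inhibitor, a lower number a stronger inhibitor. Compound 1 `O=C(O)CCC(=O)OCCCCCCSc1ccc([N+](=O)[O-])c2nonc12` gives 160 nM in this assay. Compound 2 `O=C(CCC(=O)OCCCCCCSc1ccc([N+](=O)[O-])c2nonc12)Nc1ccccc1Cl`, which carries a 2-chlorophenyl group on the amide-type nitrogen, gives 330 nM. Compound 3 `O=C(CCC(=O)OCCCCCCSc1ccc([N+](=O)[O-])c2nonc12)Nc1ccc(F)c(Cl)c1`, which carries a 3-chloro-4-fluorophenyl group there, gives 470 nM, the highest of the three numbers; against compound 1 it reads a 2.9-fold higher number from compound 1 to compound 3 (0.47 log units; beyond the scatter), while the step of a 1.4-fold higher number from compound 2 to compound 3 (0.15 log units; within the scatter) lies within the scatter. Compound 4 `CN(C)CCCNC(=O)CCC(=O)OCCCCCCSc1ccc([N+](=O)[O-])c2nonc12` differs from compound 3 in one place: 3-(dimethylamino)propyl in place of 3-chloro-4-fluorophenyl on an amide-type nitrogen. Within the data shown here, no measured step exchanges an aryl group for an open chain on that nitrogen. Among the measured compounds shown here, the steps that start from the hydroxy compound, a 2.1-fold higher number from compound 1 to compound 2 (0.31 log units; beyond the scatter) and the one to compound 3 already given, show that an arylamino in place of hydroxy raised the number modestly, and the swap between the two aryl groups stayed within the scatter. The step of a 1.3-fold lower number from compound 3 to compound 4 (0.13 log units; within the scatter) is therefore expected to stay within the scatter. In this assay compound 4 is estimated at 350 nM, with a range from 130 nM to 950 nM.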

Compound 4, half-maximal inhibitory concentration: 90 nM
The estimate for compound 4 lay 3.9-fold (0.59 log units) above the measured number, outside the stated range (below it).
By their numbers in this assay, from the lowest: compounds 4 and 1 (each within the scatter of the next); then compounds 2 and 3 (each within the scatter of the next).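

In this assay, the group on the amide-type nitrogen proved able to move the number well beyond the scatter, which the swap between the two aryl groups had not shown: 3-(dimethylamino)propyl gave lower numbers than the 3-chloro-4-fluorophenyl group (a 5.2-fold lower number from compound 3 to compound 4 (0.72 log units; beyond the scatter)) and the 2-chlorophenyl group (a 3.7-fold lower number from compound 2 to compound 4 (0.56 log units; beyond the scatter)). The rise seen with an arylamino in place of hydroxy did not carry over to this open-chain amine (a 1.8-fold lower number from compound 1 to compound 4 (0.25 log units; within the scatter)). Nothing at hand accounts for the gap between this chain and the aryl groups.

The compounds shown leave open whether the lower number belongs to the dimethylamino group or to the open chain itself, which a plain propyl or a morpholine at the chain end would help separate. They also leave open how a shorter or longer chain carrying the same amine would read.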